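The compounds below may be only part of what the source reports. "The series", "measured", "known", "first", "only" and "open" are said of these compounds alone.

Working notes on the series. Compound 1 `COc1ccc(/C=C/C(=O)c2sc(Nc3ccc(Cl)c(Cl)c3)nc2C)cc1` in a functional assay on PC-3 cells (Homo sapiens) for cytotoxicity, read by MTT assay (a lower number here means a stronger inhibitor, a higher number a weaker inhibitor), gives only a limit, > 25000 nM. Compound 2 `COc1cccc(/C=C/C(=O)c2sc(Nc3cccc(Cl)c3)nc2C)c1` in this assay likewise returns a limit, > 25000 nM. Compound 3 `COc1ccc(/C=C/C(=O)c2sc(Nc3ccc(Cl)cc3)nc2C)cc1` in this assay also stops at a limit, > 25000 nM. Going by the values given here, the single one-point step among the measured compounds, a step that the two limits leave unreadable from compound 1 to compound 3, cannot be sized, as the limit of > 25000 nM in this assay, at which 3 of the 3 values shown sit, shows. Compound 4 `Cc1nc(Nc2ccc(Cl)c(Cl)c2)sc1C(=O)/C=C/c1ccccc1` differs from compound 1 by hydrogen in place of methoxy on an aromatic carbon. Among the compounds with values here, no measured step covers this change, and the one step known gives no readable size. In this assay compound 4 is therefore expected to sit at or beyond the limit as well, so the step that the limit leaves unreadable from compound 1 to compound 4 is estimated as none beyond the scatter. The estimate for compound 4 is 30000 nM, with a range from 15000 nM to 100000 nM.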

Compound 4, half-maximal inhibitory concentration: 7990 nM
For compound 4 the middle estimate is 3.8-fold (0.57 log units) above the measured one; the measured number lies below the stated range.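

Hydrogen in place of methoxy at this position, para to a large group, gives the first readable step of the series in this assay: an at least 3.1-fold lower number from compound 1 to compound 4 (0.49 log units; beyond the scatter). The 4-methoxyphenyl to phenyl change therefore moves the read-out off the limit, which the chloro change between compound 1 and compound 3 could not show. The true size of the step stays open, and the other compounds add no readable step: the limit of > 25000 nM in this assay, at which 3 of the 4 values shown sit.

On these data alone, whether a hydroxyl, a fluoro or an amine at this position would behave like hydrogen or like methoxy remains open. Also open, as far as these compounds go, is whether the same change carries over to compound 3.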